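The source may report more compounds than this note shows. Statements on the series, on what has been measured and on what is new or still open speak of the compounds shown alone.

In an ADME assay on microsomes from liver (Mus musculus, strain CD-1) for metabolic stability, read by LC-MS, tested at 2 uM (a higher number here means that the compound lasts longer, a lower number that the compound disappears faster), the three measured compounds give:
compound 1 `CN1CCC(CNS(=O)(=O)c2ccccc2Nc2cc(-c3ccc4ccn(C)c4c3)c3nccnc3c2)C1`: 0.633 h
compound 2 `CN(C)S(=O)(=O)c1ccccc1Nc1cc(-c2ccc3ccn(C)c3c2)c2nccnc2c1`: 0.233 h
compound 3 `Cn1ccc2ccc(-c3cc(Nc4ccccc4S(=O)(=O)N4CCOCC4)cc4nccnc34)cc21`: 0.367 h

Compound 1 has the highest number of the three in this assay, though its gap to compound 3 is within the scatter; only compound 2 sits clearly lower, a 2.7-fold lower number from compound 1 to compound 2 (0.43 log units; beyond the scatter). Compound 4 `Cn1ccc2ccc(-c3cc(Nc4ccccc4S(=O)(=O)NCC4CCOCC4)cc4nccnc34)cc21` differs from compound 1 in one place: oxan-4-yl in place of 1-methylpyrrolidin-3-yl on a saturated chain carbon bound to a sulfonamide nitrogen. For the measured compounds named here, no measured step changes this ring alone. The measured steps replace the whole group on the sulfonamide nitrogen: a 1.7-fold lower number from compound 1 to compound 3 (0.24 log units; within the scatter) and a 1.6-fold higher number from compound 2 to compound 3 (0.20 log units; within the scatter) are both within the scatter, and only a 2.7-fold lower number from compound 1 to compound 2 (0.43 log units; beyond the scatter) goes beyond it. The step expected in this assay for compound 4 is therefore small, not beyond the scatter, if anything slightly lower, a 1.3-fold lower number from compound 1 to compound 4 (0.10 log units; within the scatter). Compound 4 is thus estimated at 0.5 h, in the range 0.25 h to 1 h.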

Compound 4, half-life: 0.3 h
Estimate against measurement, compound 4: 1.7-fold (0.22 log units) above; measured number inside the range.
By their numbers in this assay, from the lowest: compounds 2, 4, 3 and 1 (each within the scatter of the next, the first and the last beyond it).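

In this assay, for the compounds shown here, exchanging only the ring on the saturated chain carbon gives a 2.1-fold lower number from compound 1 to compound 4 (0.32 log units; beyond the scatter), the first step to isolate this ring, and it lies beyond the scatter. On the sulfonyl sulfur, ((oxan-4-yl)methyl)amino stays close to morpholin-4-yl and dimethylamino, with a 1.2-fold lower number from compound 3 to compound 4 (0.09 log units; within the scatter) and a 1.3-fold higher number from compound 2 to compound 4 (0.11 log units; within the scatter) both within the scatter. No measurement shown here explains the difference between these rings.

From the compounds shown here alone, since 1-methylpyrrolidin-3-yl and oxan-4-yl differ in both ring size and hetero atom, the contribution of each remains open. A 1-methylpiperidin-4-yl ring would keep the nitrogen in a six-membered ring and separate the two.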